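The source may report more compounds than this note shows. Statements on the series, on what has been measured and on what is new or still open speak of the compounds shown alone.

Compound 1 `O=C(/C=C/c1ccc2c(c1)B(O)OC2)c1ccccc1O` carries a 2-hydroxyphenyl on its carbonyl carbon. In an ADME assay on L929 cells (Mus musculus) for cytotoxicity, read by resazurin assay, with a stated time of 72 h (a lower number here means a stronger inhibitor, a higher number a weaker inhibitor), compound 1 gives only a limit, > 10 ug/mL, and no number. Two further compounds were run in this assay. Compound 2 `COc1cccc(C(=O)/C=C/c2ccccc2)c1`, built on a different core, gives 5.7 ug/mL in this assay. Compound 3 `Cc1ccc(C(=O)/C=C/c2ccc3c(c2)B(O)OC3)cc1C` keeps the same core and reaches only a limit, > 10 ug/mL, in this assay. Compound 1 thus stands at the limit of > 10 ug/mL in this assay, at which 2 of the 3 values shown sit. For the measured compounds named here, no step between two measured compounds differing in one place is available here. The unmeasured compound 4 `O=C(/C=C/c1ccc2c(c1)B(O)OC2)c1ccc(I)cc1` differs from compound 1 by 4-iodophenyl in place of 2-hydroxyphenyl on a carbonyl carbon. Compound 3 suggests that a different group on the carbonyl carbon can leave the limit untouched, though compound 2, with another core, does give a number. The step that the limit leaves unreadable from compound 1 to compound 4 is expected to stay within the scatter, with no clear direction. Compound 4 is estimated at 12 ug/mL, within a range from 4 ug/mL to 30 ug/mL, and a limit may well be reported again.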

Compound 4, half-maximal inhibitory concentration: > 10 ug/mL
Compound 4: a limit, no number; the forecaster's own chance of this, stated with the estimate: 55%; the middle value lies beyond the limit too.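

For the compounds shown here, compound 1 and compound 4 both give only a limit in this assay, so no step between them can be read. As far as these compounds go, compound 4 joins that group: the limit of > 10 ug/mL in this assay, at which 3 of the 4 values shown sit. Still open is whether 4-iodophenyl in place of 2-hydroxyphenyl on a carbonyl carbon changes the read-out at all.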